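A few compounds are considered here, and "the series" means these few. Any claim that something is new, unique, unknown or untested is made for them only; others in the source may bear on it.

Of the compounds shown here, three with a shared core have been measured, and a fourth awaits its number. Compound 1 `Fc1ccc(C(F)(F)F)cc1Nc1nc2nonc2nc1Nc1cc(C(F)(F)F)ccc1F` is recorded in an assay on mitochondria from L6 cells (Rattus norvegicus) for activation, with a stated time of 90 min (on this read-out lower numbers stand for an effect already at smaller amounts and higher numbers for an effect only at larger amounts of compound), only as a limit, giving < 1000 nM. Compound 2 `CCc1ccc(Nc2nc3nonc3nc2Nc2ccc(CC)cc2)cc1` gives 3900 nM in this assay. Compound 3 `Fc1ccccc1Nc1nc2nonc2nc1Nc1ccccc1` gives 2200 nM in this assay, the lowest of the two numbers shown, though compound 2 sits within the usual scatter of it. Compound 4 `Cc1cccc(Nc2nc3nonc3nc2Nc2ccccc2F)c1` differs from compound 3 by methyl in place of hydrogen on an aromatic carbon, a change of a single carbon and no ring. Going by the values given here, no measured pair shows a step of this kind, so the expectation rests on how small the change is. For compound 4 the estimated value is 2000 nM, spanning from 800 nM to 5000 nM. The expected step of a 1.1-fold lower number from compound 3 to compound 4 (0.04 log units; within the scatter) should stay within the scatter.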

Compound 4, half-maximal effective concentration: 1500 nM
For compound 4 the middle estimate is 1.3-fold (0.12 log units) above the measured one; low and high end bracket the measured number.
By their numbers in this assay, from the lowest: compounds 4, 3 and 2 (each within the scatter of the next, the first and the last beyond it). At a limit, below all of these: compound 1.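

Going by these compounds alone, the first single-place change that can be read in this assay is methyl in place of hydrogen on an aromatic carbon, meta to a large group, with a 1.5-fold lower number from compound 3 to compound 4 (0.17 log units; within the scatter). Within the data shown here, this shows that the position accepts a methyl without a step beyond the scatter, which no earlier pair could show. Compound 1 stands only as a limit, not as a number: the limit of < 1000 nM in this assay, at which 1 of the 4 values shown sits.

Going by these compounds, whether an amine, a carboxylic acid or a longer chain at this place would give a step beyond the scatter stays open. Also open, on these data alone, is whether methyl on another carbon of that ring would read the same.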